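Ketoamide series: aromatic amide substituent, compound 4

The source may hold more compounds than are shown below. What is called first, only, known or untested is meant among the compounds shown, and "the series" means these compounds.

Measured compounds:
- compound 1 `CCC(NC(=O)C(CC(C)C)NC(=O)OCc1ccccc1)C(=O)C(=O)NCCCCCO`; in an assay on isolated protein (Oryctolagus cuniculus) for inhibition of Calpain-2 catalytic subunit (Homo sapiens) (a higher number here means a weaker inhibitor, a lower number a stronger inhibitor), compound 1 gives 51 nM
- compound 2 `CCC(NC(=O)C(CC(C)C)NC(=O)OCc1ccccc1)C(=O)C(=O)NCC1(C)CC(O)CC(C)(C)C1`; in this assay compound 2 gives 69 nM
- compound 3 `CCC(NC(=O)C(CC(C)C)NC(=O)OCc1ccccc1)C(=O)C(=O)NCc1cc(OC)cc(OC)c1`; in this assay compound 3 gives 22 nM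

Compound 2 gives the highest number of the three. One of its gaps is small (a 1.4-fold higher number from compound 1 to compound 2 (0.13 log units; within the scatter)), while the other is clearly larger (a 3.1-fold lower number from compound 2 to compound 3 (0.50 log units; beyond the scatter)). Going by the values given here, the only change beyond the scatter in the set is the move to the aromatic substituent, seen also in a 2.3-fold lower number from compound 1 to compound 3 (0.37 log units; beyond the scatter).

Compound 4 `CCC(NC(=O)C(CC(C)C)NC(=O)OCc1ccccc1)C(=O)C(=O)NCc1nccc2ccccc12` differs from compound 2 only at the amide-type nitrogen end: a group of 10 heavy atoms (9 carbon, 1 nitrogen; one six-membered aromatic ring of carbon only, one six-membered aromatic ring with 1 hetero atom) in place of a group of 10 heavy atoms (9 carbon, 1 oxygen; one six-membered non-aromatic ring of carbon only), on a saturated chain carbon bound to an amide-type nitrogen. The step that bears most directly on this is from compound 2 to compound 3, where a six-membered aromatic ring in place of the non-aromatic ring gave a 3.1-fold lower number from compound 2 to compound 3 (0.50 log units; beyond the scatter). Among the compounds with values here, compound 4 likewise brings aromatic rings in place of the non-aromatic ring, so a lower number in this assay is expected, of similar modest size, though no measured compound carries the isoquinolin-1-yl group and the range is therefore kept wide.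

Compound 4 is estimated at 30 nM, between 12 nM and 80 nM, which means an expected step of a 2.3-fold lower number from compound 2 to compound 4 (0.36 log units; beyond the scatter).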

Compound 4, inhibition constant: 150 nM
Estimate against measurement, compound 4: 5.0-fold (0.70 log units) below; the measured number lies above the stated range.
By their numbers in this assay, from the lowest: compound 3; then compounds 1 and 2 (each within the scatter of the next); then compound 4.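

Aromatic rings at this position do not in themselves give a lower number in this assay: 3,5-dimethoxyphenyl gave a 3.1-fold lower number from compound 2 to compound 3 (0.50 log units; beyond the scatter), whereas isoquinolin-1-yl gives a 2.2-fold higher number from compound 2 to compound 4 (0.34 log units; beyond the scatter) and also a 2.9-fold higher number from compound 1 to compound 4 (0.47 log units; beyond the scatter), so compound 4 goes against any aromatic trend suggested by compound 3. The exchange of one aromatic group for the other, on a saturated chain carbon bound to an amide-type nitrogen, gives a 6.8-fold higher number from compound 3 to compound 4 (0.83 log units; beyond the scatter), the largest step in the set, which shows that the identity of the aromatic group counts for more here than the presence of an aromatic ring. No available measurement explains the difference in behaviour of these two aromatic groups.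

Still open, going by these compounds, is whether the higher number of compound 4 goes with the ring nitrogen or with the second fused ring, a question that naphthalen-1-yl, with carbon-only rings, and pyridin-2-yl, with a single ring holding nitrogen, would help to separate. Unsubstituted phenyl at the same place would likewise show how much of the lower number of compound 3 goes with its two methoxy groups.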